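Aryl substituent swaps in the dienone series

The source may report more compounds than this note shows. Statements on the series, on what has been measured and on what is new or still open speak of the compounds shown alone.

Compound 3 `CC1=C(/C=C/C(=O)/C=C/c2ccccc2Cl)C(C)(C)CCC1` in a functional assay on Hep cells (Homo sapiens) for cytotoxicity, read by sulforhodamine B assay, with a stated time of 48 h (a lower number here means a stronger inhibitor, a higher number a weaker inhibitor), gives 54200 nM, the smallest number of the three measured, though the other two sit within the scatter of it: compound 2 `CC1=C(/C=C/C(=O)/C=C/c2ccc(F)cc2)C(C)(C)CCC1` gives 55800 nM and compound 1 `CC1=C(/C=C/C(=O)/C=C/c2ccccc2)C(C)(C)CCC1` gives 62200 nM. The steps of a 1.1-fold lower number from compound 1 to compound 2 (0.05 log units; within the scatter), a 1.1-fold lower number from compound 1 to compound 3 (0.06 log units; within the scatter) and a 1.0-fold lower number from compound 2 to compound 3 (0.01 log units; within the scatter) all stay within the scatter, so the aromatic substituents tried so far leave this assay flat. Compound 4 `COc1ccccc1/C=C/C(=O)/C=C/C1=C(C)CCCC1(C)C` differs from compound 3 by methoxy in place of chloro on an aromatic carbon. Within the data shown here, the closest precedent is the chloro entering on an aromatic carbon in a 1.1-fold lower number from compound 1 to compound 3 (0.06 log units; within the scatter); no measured step covers a methoxy group. The expected step of a 1.0-fold higher number from compound 3 to compound 4 (0.01 log units; within the scatter) therefore lies within the scatter. Compound 4 is estimated at 55000 nM, with a range of 30000 nM to 100000 nM.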

Compound 4, half-maximal inhibitory concentration: 38900 nM
Compound 4: the middle estimate sits 1.4-fold (0.15 log units) above what was measured, and the stated range covers the measured number.
By their numbers in this assay, from the lowest: compounds 4, 3, 2 and 1 (each within the scatter of the next).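

Methoxy on this aromatic carbon, ortho to a large group, brings a hydrogen-bond acceptor in place of chloro, yet this assay still shows only a step within the scatter (a 1.4-fold lower number from compound 3 to compound 4 (0.14 log units; within the scatter)). Set against the unsubstituted aryl group, the same substituent also stays within the scatter (a 1.6-fold lower number from compound 1 to compound 4 (0.20 log units; within the scatter)), so the flat picture now extends to a substituent of two heavy atoms. Going by these compounds, whether an amine, a carboxylic acid or a longer chain at this position would move the number beyond the scatter stays open, as does the effect of any change to the shared core. No measured evidence bears on these results.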